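Aryl exchange on the shared core: expectation for compound 3

The source may hold more compounds than are shown below. What is called first, only, known or untested is meant among the compounds shown, and "the series" means these compounds.

Measured so far:
compound 1 `CC(C)OC(=O)N1CCC(Oc2ncnc3c2CCN3c2ccc(C#N)cc2F)CC1` — 63.1 nM
compound 2 `CC(C)OC(=O)N1CCC(Oc2ncnc3c2CCN3c2ccc([S@+](C)[O-])c(F)c2)CC1` — 50.1 nM

Both numbers come from a functional assay on CHO-K1 cells for agonist activity at Glucose-dependent insulinotropic receptor (Homo sapiens), read by a luciferase reporter, with a stated time of 5 h; a lower number here means that less compound is needed, a higher number that more compound is needed for the effect. Compound 1 gives 63.1 nM and compound 2 gives 50.1 nM; the two values lie within the scatter of each other, the step being a 1.3-fold lower number from compound 1 to compound 2 (0.10 log units; within the scatter). Compound 2 therefore stands alongside compound 1 with no separation that can be read as real.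

Compound 3 `Cc1cc(S(C)(=O)=O)ccc1N1CCc2c(OC3CCN(C(=O)OC(C)C)CC3)ncnc21` differs from compound 2 only in the aryl group on the nitrogen on an aromatic ring in a ring: a group of 11 heavy atoms (8 carbon, 2 oxygen, 1 sulfur; one six-membered aromatic ring of carbon only) in place of a group of 10 heavy atoms (7 carbon, 1 oxygen, 1 fluorine, 1 sulfur; one six-membered aromatic ring of carbon only), on a nitrogen on an aromatic ring in a ring. Going by the values given here, the single step measured to date, a 1.3-fold lower number from compound 1 to compound 2 (0.10 log units; within the scatter), is the same kind of change, an exchange of the aryl group at this position, and it did not move the number beyond the scatter. On that basis the step expected in this assay is a 1.0-fold lower number from compound 2 to compound 3 (0.00 log units; within the scatter), within the scatter. The estimate for compound 3 is 50 nM, with a range from 15 nM to 170 nM.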

Compound 3, half-maximal effective concentration: 100 nM
The estimate for compound 3 lay 2.0-fold (0.30 log units) below the measured number; the measured number falls inside the stated range.
By their numbers in this assay, from the lowest: compounds 2, 1 and 3 (each within the scatter of the next).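

In this assay, placing 2-methyl-4-(methylsulfonyl)phenyl on this nitrogen gives a 2.0-fold higher number from compound 2 to compound 3 (0.30 log units; within the scatter) and a 1.6-fold higher number from compound 1 to compound 3 (0.20 log units; within the scatter). The position now carries three different aryl groups with no separation that can be read as real, and compound 3 shows that an aryl group without fluorine also stays within this scatter. Nothing available bears on the reason for these numbers.

Compound 3 differs from compound 2 in more than one feature of the aryl group, so the contributions of the methyl group and of the sulfonyl group cannot be told apart. Going by these compounds, whether an amine, a carboxylic acid or a longer chain on this aryl ring would give a number beyond the scatter remains open.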